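The compounds below may be only part of what the source reports. "The series", "measured", "known", "first", "only" and "open" are said of these compounds alone.

In a functional assay on MCF7 cells (Homo sapiens) (a higher number here means a weaker inhibitor of growth, a lower number a stronger inhibitor of growth), compound 1 `O=S(=O)(/C=C/c1ccc(F)cc1)Cc1ccc(Nc2ncnc3ccccc23)cc1` gives 16000 nM, compound 2 `O=S(=O)(/C=C/c1ccc(Br)cc1)Cc1ccc(Nc2ncnc3ccccc23)cc1` gives 91000 nM and compound 3 `CC(C)(C)c1cc(/C=C/S(=O)(=O)Cc2ccc(Nc3ncnc4ccccc34)cc2)cc(C(C)(C)C)c1O` gives 13000 nM. Compound 2 therefore has the highest number of the three, making it the weakest inhibitor of growth among them.

The next compound, compound 4 `O=S(=O)(/C=C/c1ccc(F)cc1Cl)Cc1ccc(Nc2ncnc3ccccc23)cc1`, differs from compound 2 by one change: 2-chloro-4-fluorophenyl in place of 4-bromophenyl on a double-bonded chain carbon bound to a double-bonded chain carbon. In words, 2-chloro-4-fluorophenyl stands in place of 4-bromophenyl on a double-bonded chain carbon bound to a double-bonded chain carbon.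

Among the compounds with values here, one measured step bears on this change. Putting bromo in place of fluoro on an aromatic carbon gave a 5.7-fold higher number from compound 1 to compound 2 (0.75 log units; beyond the scatter), a modest step beyond the scatter. Compound 4 carries fluoro again, so that step, read backwards, points towards a lower number. Within the data shown here, no measured compound shows what the added chloro does, which leaves the estimate wide.

A step of similar size is therefore expected, namely a 4.6-fold lower number from compound 2 to compound 4 (0.66 log units; beyond the scatter). The estimated value for compound 4 is 20000 nM, with an expected range of 7000 nM to 60000 nM.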

Compound 4, concentration for 50% growth inhibition: 21000 nM
Estimate against measurement, compound 4: 1.1-fold (0.02 log units) below; measured number inside the range.
By their numbers in this assay, from the lowest: compounds 3, 1 and 4 (each within the scatter of the next); then compound 2.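

In this assay chloro in place of hydrogen on an aromatic carbon gives a 1.3-fold higher number from compound 1 to compound 4 (0.12 log units; within the scatter) and leaves the two numbers within the scatter of each other, which settles what the added chloro does on this fluoro-bearing ring. The full exchange of 4-bromophenyl for 2-chloro-4-fluorophenyl gives a 4.3-fold lower number from compound 2 to compound 4 (0.64 log units; beyond the scatter) and lies beyond the scatter, so with the chloro step this small, compound 2 remains the weakest inhibitor of growth of the four. Nothing measured here gives a reason for either step.

On these data alone, whether chloro would behave the same way on the 4-bromophenyl of compound 2 stays open. Also open, as far as these compounds go, is how a methoxy group, a nitrile or an amine would fare in place of these halogens on the ring.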